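Methyl for methoxy on the benzylamide ring

The compounds below may be only part of what the source reports. "The series", "measured", "known", "first", "only" and "open" are said of these compounds alone.

Three analogues of one core have been measured for growth inhibition in a functional assay on NCI-H1975 cells (Homo sapiens) for antiproliferative activity, with a stated time of 72 h; a higher number here means a weaker inhibitor of growth, a lower number a stronger inhibitor of growth. Compound 1 `CNC(=O)c1ccc(CN(C)C(=O)c2cc(Cl)c(O)cc2O)cc1` gives 34800 nM, compound 2 `Cc1cccc(CN(C)C(=O)c2cc(Cl)c(O)cc2O)c1` gives 49300 nM, and compound 3 `COc1ccc(CN(C)C(=O)c2cc(Cl)c(O)cc2O)cc1` gives 16700 nM, the lowest of the three numbers. Within the data shown here, the only single-point step among them is a 2.1-fold lower number from compound 1 to compound 3 (0.32 log units; beyond the scatter), a modest gain. Compound 4 `Cc1ccc(CN(C)C(=O)c2cc(Cl)c(O)cc2O)cc1` differs from compound 3 by methyl in place of methoxy on an aromatic carbon. Among the measured compounds shown here, no measured step mirrors this exchange; the closest guide is compound 2, which also carries a methyl on the same ring and gives 49300 nM, a higher number than compound 3 gives. Since compound 3 reached the best value with the methoxy, and the one methyl-bearing comparator sits higher, the change is expected to cost some potency, though the evidence is thin. Compound 4 is estimated to show a 1.5-fold higher number from compound 3 to compound 4 (0.18 log units; within the scatter) in this assay, landing at 25000 nM, with a range from 10000 nM to 60000 nM.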

Compound 4, concentration for 50% growth inhibition: 34300 nM
Compound 4: the middle estimate sits 1.4-fold (0.14 log units) below what was measured; low and high end bracket the measured number.
By their numbers in this assay, from the lowest: compound 3; then compounds 4, 1 and 2 (each within the scatter of the next).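

In this assay, among these compounds, the step of a 2.1-fold higher number from compound 3 to compound 4 (0.31 log units; beyond the scatter) gives the first direct comparison of methoxy and methyl on an aromatic carbon para to a large group, and methoxy gives the lower number of this pair. The step of a 1.4-fold lower number from compound 2 to compound 4 (0.16 log units; within the scatter) does not separate 4-methylphenyl from 3-methylphenyl, and the step of a 1.0-fold lower number from compound 1 to compound 4 (0.01 log units; within the scatter) does not separate methyl from methylcarbamoyl at this position, so of these groups methoxy alone stands apart. The data shown offer no explanation for the gap between methoxy and methyl.

The compounds shown leave open whether ethoxy or hydroxy at this place would match compound 3. They also leave open whether a chlorine or an amine there would fall with methoxy or with methyl.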